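The source may hold more compounds than are shown below. What is called first, only, known or untested is meant among the compounds shown, and "the series" means these compounds.

Compound 1, `CCc1ccc(NC2=CC(=O)c3nc4n(c3C2=O)[C@H]2OC[C@@H](O)[C@H]2OC4)cc1`, in a functional assay on HeLa cells (Homo sapiens) for inhibition, read by sulforhodamine B assay (on this read-out higher numbers stand for weaker inhibition and lower numbers for stronger inhibition), gives 3990 nM.
Compound 2, `O=C1C(N2CCCC2)=CC(=O)c2c1nc1n2[C@H]2OC[C@@H](O)[C@H]2OC1`, in this assay gives > 16000 nM, a limit of the assay and not a number.
Compound 3, `COc1ccc(NC2=CC(=O)c3nc4n(c3C2=O)[C@H]2OC[C@@H](O)[C@H]2OC4)cc1`, in this assay gives 4780 nM.

Among the measured compounds shown here, compound 2 stands at the limit of > 16000 nM in this assay, at which 1 of the 3 values shown sits; it is the one compound here without a numerical value. For the measured compounds named here, the one measured step, a 1.2-fold higher number from compound 1 to compound 3 (0.08 log units; within the scatter), lies within the scatter and concerns a substituent exchange on an aromatic carbon, so it shows only that compounds 1 and 3 sit close to each other.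

Compound 4, `O=C1C(Nc2cccc(F)c2)=CC(=O)c2c1nc1n2[C@H]2OC[C@@H](O)[C@H]2OC1`, differs from compound 2 by (3-fluorophenyl)amino in place of pyrrolidin-1-yl on a double-bonded ring carbon. Going by the values given here, no measured step covers this exchange. What the data offer is that compounds 1 and 3, whose structures stand above and which resemble compound 4 more closely than compound 2 does, both give numbers near each other, while compound 2 gives only a limit. Compound 4 is therefore expected to move down from the limit into the range of compounds 1 and 3, an estimated step of an at least 3.5-fold lower number from compound 2 to compound 4 (0.55 log units; beyond the scatter). The estimate for compound 4 is 4500 nM, within 1800 nM to 12000 nM.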

Compound 4, half-maximal inhibitory concentration: > 8000 nM
Compound 4: no number, only a limit; the forecaster's own chance of this, stated with the estimate: 12%; middle value at least 1.7-fold (0.24 log units) away from the limit.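

In this assay compound 2 gives > 16000 nM, a limit and not a number. Compound 4 gives > 8000 nM, also a limit, so the step between compound 2 and compound 4 cannot be read. The compounds shown leave open whether (3-fluorophenyl)amino in place of pyrrolidin-1-yl changes inhibition at all.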